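Swapping the Aryl Group on Compound 1

The compounds below may be only part of what the source reports. "The series", "measured", "known", "first", "only" and "open" are said of these compounds alone.

Measured so far:
compound 1, `COc1ccccc1CN(C)CCCCn1c(=O)oc2ccccc21`, with 594 nM
compound 2, `O=C(Nc1ccccc1)C1CCN(Cc2ccccc2)CC1`, with 48.1 nM

Both compounds were tested in an assay on membranes from liver for displacement of a labelled ligand from Sigma non-opioid intracellular receptor 1 (Rattus norvegicus), read by scintillation counting; on this read-out higher numbers stand for weaker inhibition and lower numbers for stronger inhibition. Compound 1 stands at the highest of the two numbers: the nearest value, that of compound 2, is lower by a gap that lies beyond the usual scatter of the assay, so compound 2 is the stronger inhibitor of the pair. For the measured compounds named here, no step between two measured compounds that differ in a single place is available, so nothing is known directly about how changes on the saturated chain carbon bound to the amine nitrogen affect the read-out.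

Compound 3, `CN(CCCCn1c(=O)oc2ccccc21)Cc1ccc(Cl)cc1`, has not yet been measured. It differs from compound 1 in one place: 4-chlorophenyl in place of 2-methoxyphenyl on a saturated chain carbon bound to an amine nitrogen. Going by the values given here, with no comparable step to draw on, the expectation rests on compound 1 alone. A modest move toward a lower number is expected, described by a 2.0-fold lower number from compound 1 to compound 3 (0.30 log units; within the scatter), though a result within the scatter of compound 1 would not surprise. The estimate for compound 3 in this assay is 300 nM, expected to fall between 80 nM and 1200 nM.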

Compound 3, inhibition constant: 7.1 nM
Compound 3: the middle estimate sits 42-fold (1.63 log units) above what was measured; the measured number lies below the stated range.
By their numbers in this assay, from the lowest: compound 3; then compound 2; then compound 1.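

In this assay, for the compounds shown here, the aryl group on a saturated chain carbon bound to an amine nitrogen turns out to matter a great deal: 4-chlorophenyl in place of 2-methoxyphenyl gives an 84-fold lower number from compound 1 to compound 3 (1.92 log units; beyond the scatter) and so supplies the first direct reading at this position. The rest of compound 1 stays the same in compound 3, so this large step, beyond the scatter, belongs to this one place, and the read-out clearly responds to what the aromatic ring carries there. No measured evidence bears on why the step is so large.

The change alters two things at once, the substituent and its numbered place on the ring, and the compounds shown do not separate them. The two groups that would separate them are 2-chlorophenyl and 4-methoxyphenyl. Also open, going by these compounds, is whether the unsubstituted phenyl group or 4-fluorophenyl would hold the number of compound 3 at this position, or whether the step depends on the chlorine itself.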